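The source may hold more compounds than are shown below. What is called first, only, known or untested is meant among the compounds shown, and "the series" means these compounds.

In a functional assay on MDA-MB-231 cells (Homo sapiens) for antiproliferative activity, read by MTT assay, with a stated time of 72 h (on this read-out higher numbers stand for weaker inhibition and lower numbers for stronger inhibition), compound 1 `CC1=CC[C@H]2[C@H](CC[C@]2(C)O)C(C)(C)[C@@H]1CC[C@H]1[C@]2(C)CC[C@H](OC(=O)CCC(=O)O)C(C)(C)O[C@H]2CC[C@@]1(C)O` gives 27900 nM and compound 2 `CC1=CC[C@H]2[C@H](CC[C@]2(C)O)C(C)(C)[C@@H]1CC[C@H]1[C@]2(C)CC[C@H](OC(=O)c3ccncc3)C(C)(C)O[C@H]2CC[C@@]1(C)O` gives 18000 nM on the shared core, while compound 3 `CC1=CC[C@H]2[C@H](CC[C@]2(C)O)C(C)(C)[C@@H]1CC[C@H]1[C@]2(C)CC[C@H](OC(=O)c3ccc(F)cc3)C(C)(C)O[C@H]2CC[C@@]1(C)O` gives 11300 nM and so stands within the scatter of compound 2 and beyond it only against compound 1. Compound 4 `CC1=CC[C@H]2[C@H](CC[C@]2(C)O)C(C)(C)[C@@H]1CC[C@H]1[C@]2(C)CC[C@H](OC(=O)c3ccc([N+](=O)[O-])cc3)C(C)(C)O[C@H]2CC[C@@]1(C)O` differs from compound 3 by nitro in place of fluoro on an aromatic carbon and carries nitro in place of fluoro on an aromatic carbon. Among the compounds with values here, the one measured exchange between aromatic groups is a 1.6-fold lower number from compound 2 to compound 3 (0.20 log units; within the scatter) and the larger 2.5-fold lower number from compound 1 to compound 3 (0.39 log units; beyond the scatter) only just passes the scatter. Within the data shown here, no measured step changes a group on that aromatic carbon. The expected change is a 1.1-fold higher number from compound 3 to compound 4 (0.03 log units; within the scatter) and so nothing beyond the scatter is expected in this assay here. Compound 4 is therefore estimated at 12000 nM with an expected range from 6000 nM to 24000 nM in this read-out.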

Compound 4, half-maximal inhibitory concentration: 8900 nM
Compound 4: middle estimate off by 1.3-fold (0.13 log units), on the high side; the range from low to high includes it.
By their numbers in this assay, from the lowest: compounds 4, 3, 2 and 1 (each within the scatter of the next, the first and the last beyond it).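

In this assay, within the data shown here, this is the first measured change on the aromatic carbon para to a large group: nitro in place of fluoro gives a 1.3-fold lower number from compound 3 to compound 4 (0.10 log units; within the scatter) and so stays within the scatter. Among the groups on the carbonyl carbon, 4-nitrophenyl gives a 2.0-fold lower number from compound 2 to compound 4 (0.31 log units; beyond the scatter) and a 3.1-fold lower number from compound 1 to compound 4 (0.50 log units; beyond the scatter) and so, unlike 4-fluorophenyl, passes the scatter against pyridin-4-yl as well as against 2-carboxyethyl. No evidence is available that would explain these steps. From the compounds shown here alone, whether an amine or a methoxy group on that aromatic carbon would move the number beyond the scatter remains open, as does the effect of a longer chain between the carbonyl and the ring.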